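The compounds below may be only part of what the source reports. "The series", "measured", "known", "first", "only" and "open" are said of these compounds alone.

Measured compounds and their values in an assay on isolated protein for binding affinity to somatostatin receptor type 1 (Homo sapiens); a higher number here means weaker binding, a lower number tighter binding:
- compound 1, `C[C@@H](Cc1ccc2ocnc2c1)CN1C[C@@H]2CCCC[C@@H]2[C@H](C(=O)N2CCN(c3ccc(F)c(F)c3)CC2)C1`, 1620 nM
- compound 2, `C[C@@H](Cc1ccc2nccnc2c1)CN1C[C@@H]2CCCC[C@@H]2[C@H](C(=O)N2CCN(c3ccc(F)c(F)c3)CC2)C1`, 2630 nM

Compound 2 shows the highest of the two numbers in this assay; its nearest neighbour is compound 1, and the gap between them, a 1.6-fold higher number from compound 1 to compound 2 (0.21 log units; within the scatter), lies within the scatter. Compound 3, `CCNc1ccc(C[C@H](C)CN2C[C@@H]3CCCC[C@@H]3[C@H](C(=O)N3CCN(c4ccc(F)c(F)c4)CC3)C2)cn1`, differs from compound 2 in one place: 6-(ethylamino)pyridin-3-yl in place of quinoxalin-6-yl on a saturated chain carbon, three bonds along the chain from an amine nitrogen in a ring. Going by the values given here, the only measured step that bears on this position is a 1.6-fold higher number from compound 1 to compound 2 (0.21 log units; within the scatter), an exchange of one aromatic ring system for another on the same saturated chain carbon, and it stayed within the scatter. On that basis no step beyond the scatter is expected for compound 3 in this assay, the expected step being a 1.2-fold lower number from compound 2 to compound 3 (0.08 log units; within the scatter). Compound 3 is therefore estimated at 2200 nM, with a range from 900 nM to 5500 nM.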

Compound 3, dissociation constant: 1910 nM
Compound 3: the middle estimate sits 1.2-fold (0.06 log units) above what was measured, within the range that was stated.
By their numbers in this assay, from the lowest: compounds 1, 3 and 2 (each within the scatter of the next).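

Compound 3 changes more at this position than the earlier pair did: the 6-(ethylamino)pyridin-3-yl group has one aromatic ring where quinoxalin-6-yl has two, and it brings a hydrogen-bond donor. Even so, this assay gives a 1.4-fold lower number from compound 2 to compound 3 (0.14 log units; within the scatter) and, against the 1,3-benzoxazol-5-yl group, a 1.2-fold higher number from compound 1 to compound 3 (0.07 log units; within the scatter), so a single-ring group with a donor reads the same here as the two-ring groups without one. Nothing at hand explains why these groups read alike.

The compounds shown leave open whether the ethylamino group itself matters, as against a plain pyridin-3-yl or a 6-methoxypyridin-3-yl group. They also leave open whether a saturated ring such as cyclohexyl, or a longer chain before the aromatic ring, would move the number beyond the scatter.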